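The source may report more compounds than this note shows. Statements on the series, on what has been measured and on what is new or still open speak of the compounds shown alone.

Compound 1 `COc1ccc2[nH]c(C(=O)N3CC(=O)N(Cc4ccccc4)[C@@H](CN4CCCCC4)C3)cc2c1` — in a physicochemical assay for solubility, read by spectrophotometry, in phosphate buffer, with a stated time of 2 h, at pH 7.4 (on this read-out lower numbers stand for lower solubility and higher numbers for higher solubility), compound 1 gives > 25000 nM, which is a limit of the assay and not a number.
Compound 2 `COc1ccc2[nH]c(C(=O)N3CC(=O)N(Cc4ccccc4)[C@@H](CN4CCC(C)CC4)C3)cc2c1` — in this assay compound 2 gives 93100 nM.
Compound 3 `COc1ccc2[nH]c(C(=O)N3CC(=O)N(Cc4ccccc4)[C@@H](CN4CCCC4)C3)cc2c1` — in this assay compound 3 gives > 25000 nM, again a limit and not a number.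

Compound 3 therefore stands at the limit, where two of the three values shown sit, see (the limit of > 25000 nM in this assay, at which 2 of the 3 values shown sit). Among the measured compounds shown here, compound 2 is the only compound with a read number. The measured steps are a step that the limit leaves unreadable from compound 1 to compound 2, a step that the two limits leave unreadable from compound 1 to compound 3 and a step that the limit leaves unreadable from compound 2 to compound 3; none of them has a readable size, so the set gives no step size to carry over.

Compound 4 `COc1ccc2[nH]c(C(=O)N3CC(=O)N(Cc4ccccc4)[C@@H](Cc4ccccn4)C3)cc2c1` differs from compound 3 by pyridin-2-yl in place of pyrrolidin-1-yl on a saturated chain carbon bound to a saturated ring carbon. For the measured compounds named here, no measured step covers this kind of exchange; the known steps only vary the saturated ring on the same chain carbon. With compound 3 at a limit, the size of the step cannot be anchored on its value. The step from compound 3 to compound 4 is expected to be a step that the limit leaves unreadable from compound 3 to compound 4, with the value of compound 2 as the only numeric reference point. Compound 4 is expected to give 40000 nM in this assay, within a range from 10000 nM to 120000 nM, and a fair chance remains that only a limit is reported.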

Compound 4, solubility: > 100000 nM
Compound 4: no number, only a limit (the forecaster's own chance of this, stated with the estimate: 35%); middle value at least 2.5-fold (0.39 log units) from the limit.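

In this assay, among the compounds shown here, compound 4 is the first with an aromatic ring on the saturated chain carbon, and it reads only as a limit, not a number: the limit of > 100000 nM in this assay, at which 1 of the 4 values shown sits. Pyridin-2-yl at this place therefore gives no lower read-out than the saturated rings, though the limits of the set do not allow a ranking. For the compounds shown here, the only readable step is an at least 1.0-fold higher number from compound 2 to compound 4 (0.03 log units; that floor lies within the scatter), so pyridin-2-yl and 4-methylpiperidin-1-yl cannot be separated here, and the steps to compound 4 from compound 1 and compound 3 cannot be read.

On these data alone, what number compound 4 would give past its limit stays open, and so does any effect of the ring nitrogen within pyridin-2-yl. A plain phenyl or a morpholin-4-yl on the same chain carbon would test how far this tolerance reaches.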